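This account rests on a few compounds, and the source may have more. Where it says the series, first, only, none or still open, it means among the compounds named here.

Measured so far:
- compound 1, `Cc1ccccc1C1C(C#N)=C(N)OC(c2c[nH]c3ccccc23)=C1C#N`: 17.2%
- compound 2, `Cc1ccc(C2C(C#N)=C(N)OC(c3c[nH]c4ccccc34)=C2C#N)cc1`: 5.5%

In a functional assay, tested at 100 ug/mL (on this read-out lower numbers stand for a weaker effect and higher numbers for a stronger effect at the one concentration tested), compound 2 gives 5.5% and stands lowest of the two numbers; the nearest number is that of compound 1, which gives 17.2%. For the measured compounds named here, the one measured step is a number 11.7 percentage points lower from compound 1 to compound 2 (beyond the scatter), a modest drop tied to moving the methyl group from one position on the phenyl ring to another.

Compound 3, `COc1ccc(C2C(C#N)=C(N)OC(c3c[nH]c4ccccc34)=C2C#N)cc1`, has not been measured. It differs from compound 2 in one place: methoxy in place of methyl on an aromatic carbon. Going by the values given here, no measured step concerns an exchange of methyl for methoxy; the only step moves a methyl group and leaves the group itself unchanged, so it does not bear directly on this change. Among the compounds with values here, with no step to build on, the working assumption is no movement beyond the usual scatter, starting from the low number of compound 2.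

Compound 3 is therefore expected to give about 8%, with a range from 0% to 25%. For compound 3 this corresponds to an expected a number 2.5 percentage points higher from compound 2 to compound 3 (within the scatter).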

Compound 3, a percentage reported as activity, at one concentration (the size of the read-out at that concentration, not a potency): 20%
Beside the measured number, compound 3's estimate is 12 percentage points below it; the range from low to high includes it.
By their numbers in this assay, from the lowest: compound 2; then compounds 1 and 3 (each within the scatter of the next).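

In this assay, exchanging methyl for methoxy on the aromatic carbon para to a large group gives a number 14.5 percentage points higher from compound 2 to compound 3 (beyond the scatter), showing that the identity of the group at this place affects the read-out, whereas the earlier pair only moved the methyl group. The comparison of the two aryl groups gives a number 2.8 percentage points higher from compound 1 to compound 3 (within the scatter), so among these compounds, a group at the place para to a large group does not by itself go with the low number of compound 2. Nothing available bears on the reason for the step from methyl to methoxy.

The exchange adds an oxygen, one more heavy atom and a hydrogen-bond acceptor together, so the compounds shown do not separate which of these differences goes with the higher number of compound 3, and a single-concentration read-out says nothing of potency. Also open, from the compounds shown here alone, is how a hydroxy group, an amine or a longer chain such as ethoxy would read at this place on the same shared core.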